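A few compounds are considered here, and "the series" means these few. Any claim that something is new, unique, unknown or untested is made for them only; others in the source may bear on it.

Measured compounds in a functional assay on HeLa cells (Homo sapiens) for antiproliferative activity, read by MTT assay, with a stated time of 72 h; on this read-out higher numbers stand for weaker inhibition and lower numbers for stronger inhibition:
compound 1, `O=c1c(SC(=S)N2CCCCC2)coc2ccccc12`, gives 9000 nM.
compound 2, `O=c1cc(CSC(=S)N2CCCCC2)oc2cc(Cl)ccc12`, gives > 25000 nM, which is a limit of the assay and not a number.
compound 3, `O=c1c(CSC(=S)N2CCCCC2)coc2cc(Cl)ccc12`, gives 440 nM.

Of the two numbers in hand, compound 3 has the lower one; the nearest is compound 1, whose higher number lies beyond the scatter. For compound 2 only a limit is known, as recorded in the limit of > 25000 nM in this assay, at which 1 of the 3 values shown sits, so its placing against compound 3 cannot be read from a number. Among the measured compounds shown here, no two measured compounds differ in just one place, so no single step has been quantified within this small set.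

The next compound, compound 4, `O=c1c(CSC(=S)N2CCOCC2)coc2cc(Cl)ccc12`, carries the change (morpholin-4-yl in place of piperidin-1-yl on a thiocarbonyl carbon). For the measured compounds named here, no measured pair in this set shows what that change does, so the expectation for compound 4 rests only on the value of compound 3, 440 nM, with wide bounds. Compound 4 is expected to stay in the same region as compound 3, with a step of a 2.0-fold higher number from compound 3 to compound 4 (0.31 log units; beyond the scatter) that could fall either way and may not exceed the scatter. The estimate for compound 4 in this assay is 900 nM, between 300 nM and 3000 nM.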

Compound 4, half-maximal inhibitory concentration: 2000 nM
Compound 4: the middle estimate sits 2.2-fold (0.35 log units) below what was measured, within the range that was stated.
By their numbers in this assay, from the lowest: compound 3; then compound 4; then compound 1. At a limit, above all of these: compound 2.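

In this assay, among the compounds shown here, the exchange of piperidin-1-yl for morpholin-4-yl on a thiocarbonyl carbon gives a 4.5-fold higher number from compound 3 to compound 4 (0.66 log units; beyond the scatter) and is the first single change with a quantified effect. This position therefore responds to a change of one ring atom: with the shared core held constant, the piperidin-1-yl ring of the lower number gives way to a morpholin-4-yl ring that has one more hetero atom and one hydrogen-bond acceptor, and the number rises beyond the scatter. That difference in counts is a structural description only, and nothing in hand bears on the cause of this step.

Going by these compounds, it remains open whether other amines on the thiocarbonyl carbon, such as a piperazine, a pyrrolidine or an open-chain diethylamine, would give numbers nearer that of compound 3 or that of compound 4. For the compounds shown here, it also remains open whether the same exchange would have a step of similar size on a core other than that of compound 3, since this one pair is the only single change that can be read here.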